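This account rests on a few compounds, and the source may have more. Where it says the series, first, only, none or still open, it means among the compounds named here.

Measured so far:
- compound 1, `CN(Cc1ccccc1)C(=O)c1cc2c(Cc3ccccc3)n[nH]c2cc1O`: 980 nM
- compound 2, `CN(Cc1ccc(F)cc1)C(=O)c1cc2c(Cc3ccccc3)n[nH]c2cc1O`: 4100 nM

In a functional assay on A2780 cells (Homo sapiens) for antiproliferative activity, read by resazurin assay, with a stated time of 72 h (on this read-out lower numbers stand for stronger inhibition and higher numbers for weaker inhibition), compound 1 gives 980 nM, the lowest of the two numbers available. For the measured compounds named here, compound 2 gives 4100 nM in this assay, and the single measured step is a 4.2-fold higher number from compound 1 to compound 2 (0.62 log units; beyond the scatter). Going by the values given here, that step concerns a fluoro in place of hydrogen on an aromatic carbon of the amide substituent; it is the only comparison in the set.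

Compound 3, `CN(Cc1ccccc1)C(=O)c1cc2c(CCc3ccccc3)n[nH]c2cc1O`, has not been measured in this assay. Relative to compound 1 the change is benzyl in place of phenyl on a saturated chain carbon bound to an aromatic carbon. Among the compounds with values here, no measured step touches this part of the shared core, so the one step available does not bear on the change directly; it shows only that a small change elsewhere moved the number by a modest amount. With nothing to anchor the direction, a step of similar or smaller size is expected, with a wide range either way. The expected step is a 1.5-fold higher number from compound 1 to compound 3 (0.18 log units; within the scatter). Compound 3 is accordingly estimated at 1500 nM in this assay, within 500 nM to 5000 nM.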

Compound 3, half-maximal inhibitory concentration: 4600 nM
For compound 3 the middle estimate is 3.1-fold (0.49 log units) below the measured one; low and high end bracket the measured number.
By their numbers in this assay, from the lowest: compound 1; then compounds 2 and 3 (each within the scatter of the next).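

In this assay, the extension from benzyl to phenethyl gives a 4.7-fold higher number from compound 1 to compound 3 (0.67 log units; beyond the scatter) and so shows that this part of the shared core, which the earlier step did not touch, also responds to a small change. Lengthening the chain by this change raises the number rather than leaving it within the scatter, so the group on the saturated chain carbon bound to an aromatic carbon does not tolerate every substitution without a shift. Compound 1 now has the lowest number of the three, with its steps to both other compounds printed as beyond the scatter, and a change at either of two separate places on compound 1 has raised the number. The data shown offer no measured explanation for this rise.

From the compounds shown here alone, whether a longer chain such as phenylpropyl would raise the number further, or whether an amine or a carboxylic acid on this chain would lower it again, remains open. Also open, going by these compounds, is whether the fluoro in place of hydrogen on the amide substituent would have the same effect on the phenethyl compound.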